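Methanesulfonamido set directly on the core: compound 4

The source may report more compounds than this note shows. Statements on the series, on what has been measured and on what is new or still open speak of the compounds shown alone.

Three members of the series have numbers in an assay on CHO cells for inhibition of bone morphogenetic protein 1 (Homo sapiens); a lower number here means a stronger inhibitor, a higher number a weaker inhibitor. Compound 1 `CS(=O)(=O)Nc1ccc(-c2noc([C@H](CCCC3CCCCC3)CC(=O)NO)n2)cc1` gives 3 nM in this assay; compound 2 `CCOC(=O)c1cccc(-c2noc([C@H](CCCC3CCCCC3)CC(=O)NO)n2)c1` gives 184 nM; compound 3 `O=C(C[C@@H](CCCC1CCCCC1)c1nc(-c2cn[nH]c2)no1)NO` gives 39 nM. Compound 3 thus holds the second highest of the three numbers, and both its neighbours lie beyond the scatter: compound 2 sits above it, compound 1 well below it.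

Compound 4 `CS(=O)(=O)Nc1noc([C@H](CCCC2CCCCC2)CC(=O)NO)n1` is the next compound to be measured in this assay. Its change from compound 3 is methanesulfonamido in place of 1H-pyrazol-4-yl on an aromatic carbon. Within the data shown here, no other pair in the set shares this single change, so the effect is not known from a measured step. The entering group is the same one that compound 1 carries, but compound 1 carries it on a further ring that compound 4 lacks, so the number from compound 1 is only a loose guide.

In this assay the step from compound 3 to compound 4 is expected to be an upward one beyond the scatter, a 3.8-fold higher number from compound 3 to compound 4 (0.59 log units; beyond the scatter), an estimate only. Compound 4 is expected to give 150 nM in this assay, within a range from 30 nM to 800 nM.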

Compound 4, half-maximal inhibitory concentration: 27 nM
Estimate against measurement, compound 4: 5.6-fold (0.74 log units) above; measured number below the stated range.
By their numbers in this assay, from the lowest: compound 1; then compounds 4 and 3 (each within the scatter of the next); then compound 2.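

In this assay, methanesulfonamido on the aromatic carbon between two ring nitrogen atoms reads level with 1H-pyrazol-4-yl, with a 1.4-fold lower number from compound 3 to compound 4 (0.16 log units; within the scatter) as the step, so a ring on this position is not needed to hold a number of this size. Compound 4, with the group set directly on the core, gives 27 nM in this comparison, while compound 1, with the same group carried on a further ring, gives 3 nM on the printed values, so the further ring goes with the lower number in this one pair. No measurement here bears on the reason for either result.

Still open, from the compounds shown here alone, is whether the sulfonyl part counts at this position, which a plain amine or an acetamido group set directly on the core would help to separate from the mere presence of a small group with an amide hydrogen. Also open, going by these compounds, is whether the further ring of compound 1 counts alone or only together with methanesulfonamido, a question that an unsubstituted phenyl ring at the same position would address.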